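Anilide-substituent series: benzoyl analogue of compound 2

A few compounds are considered here, and "the series" means these few. Any claim that something is new, unique, unknown or untested is made for them only; others in the source may bear on it.

Measured in a functional assay on HCT-116 cells (Homo sapiens) for inhibition, read by colorimetric assay, with a stated time of 3 days; on this read-out higher numbers stand for weaker inhibition and lower numbers for stronger inhibition:
compound 1 `COc1ccccc1NC(=O)CCCCCCNC(=O)C(O)(O)C(F)(F)F`: 10100 nM
compound 2 `O=C(CCCCCCNC(=O)C(O)(O)C(F)(F)F)Nc1ccc(F)cc1`: 7570 nM
compound 3 `O=C(CCCCCCNC(=O)C(O)(O)C(F)(F)F)Nc1ccc(F)cc1F`: 18500 nM

Compound 2 holds the lowest number of the three in this assay; compound 1 sits within the scatter of it (a 1.3-fold lower number from compound 1 to compound 2 (0.13 log units; within the scatter)), and only compound 3 lies beyond it (a 2.4-fold higher number from compound 2 to compound 3 (0.39 log units; beyond the scatter)). Compound 4 `O=C(CCCCCCNC(=O)C(O)(O)C(F)(F)F)Nc1ccc(C(=O)c2ccccc2)cc1` differs from compound 2 by benzoyl in place of fluoro on an aromatic carbon. The measured steps all concern small substituents on that ring and were modest at most (a 1.8-fold higher number from compound 1 to compound 3 (0.26 log units; within the scatter)); none involves a group like benzoyl, so they bear only loosely on this change. No step beyond the scatter is therefore expected in this assay, with wide uncertainty: compound 4 is estimated at 6000 nM (range 1500 nM to 25000 nM), a step of a 1.3-fold lower number from compound 2 to compound 4 (0.10 log units; within the scatter) from compound 2 that is expected.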

Compound 4, half-maximal inhibitory concentration: > 40000 nM
Compound 4 gave a limit, no number; the forecaster's own chance of this, stated with the estimate: 10%; middle value at least 6.6-fold (0.82 log units) away from the limit.
By their numbers in this assay, from the lowest: compounds 2, 1 and 3 (each within the scatter of the next, the first and the last beyond it). At a limit, above all of these: compound 4.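

Benzoyl in place of fluoro gives an at least 5.2-fold higher number from compound 2 to compound 4 (0.72 log units; beyond the scatter), a wider step than any among the small substituents, so this position is not indifferent to the group it carries. Compound 4 gives a limit in this assay, not a number: the limit of > 40000 nM in this assay, at which 1 of the 4 values shown sits.

From the compounds shown here alone, the true size of the step therefore stays open. Going by these compounds, it is also open whether the change follows from the carbonyl or from the added aromatic ring, a question that acetyl or phenyl at this position would separate.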